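Methyl at a Chain Carbon in Carbamate Agonists

The source may hold more compounds than are shown below. What is called first, only, known or untested is meant among the compounds shown, and "the series" means these compounds.

Three carbamates have been tested in a functional assay on the whole organism for agonist activity, with Mus musculus as the target; a lower number here means that less compound is needed, a higher number that more compound is needed for the effect. Compound 1 `COC(=O)N(C)CC#CCn1cncc1C` gives 4.5 mg/kg. Compound 3 `CCOC(=O)N(C)CC#CCn1cncc1C` gives 97 mg/kg. Compound 2 `CCOC(=O)N(C)CC#CCN1CCCC1` gives 66 mg/kg. The difference between the cores of compound 1 and compound 2 is not broken down here. Within the shared core of compound 1 and compound 3, the change is methyl in place of hydrogen on a saturated chain carbon bound to an oxygen next to a carbonyl group, and the step of a 22-fold higher number from compound 1 to compound 3 (1.33 log units; beyond the scatter) shows a large increase in the dose needed.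

Compound 4 `CCOC(=O)N(C)C(C)C#CCN1CCCC1` has not been measured in this assay. It carries the change methyl in place of hydrogen on a saturated chain carbon bound to an amide-type nitrogen and a triple-bonded carbon relative to compound 2. Going by the values given here, this is the same kind of change as the one between compound 1 and compound 3, a methyl entering where a hydrogen leaves, but at a different place: in the measured pair the carbon is bound to an oxygen next to a carbonyl group, whereas in compound 4 the carbon is bound to an amide-type nitrogen and a triple-bonded carbon. Among the compounds with values here, because the only measured example of this kind of change, a 22-fold higher number from compound 1 to compound 3 (1.33 log units; beyond the scatter), raised the dose needed, a step in the same direction is expected from compound 2 to compound 4, though smaller and less certain since the place differs, giving an estimated 3.8-fold higher number from compound 2 to compound 4 (0.58 log units; beyond the scatter). Compound 4 is therefore expected to need about 250 mg/kg in this assay, likely between 60 mg/kg and 1500 mg/kg.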

Compound 4, dose for half-maximal effect: > 100 mg/kg
Compound 4 gave a limit, no number; the forecaster's own chance of this, stated with the estimate: 35%; the middle value is on the limit's open side.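

In this assay compound 4 gives > 100 mg/kg, which is a limit of the assay and not a number. Adding the methyl on the saturated chain carbon bound to an amide-type nitrogen and a triple-bonded carbon gives an at least 1.5-fold higher number from compound 2 to compound 4 (0.18 log units; that floor lies within the scatter), so the true step could be small enough to vanish in the scatter or far larger. The result is compatible with this kind of change raising the dose needed on both cores, but it does not show that the size of the earlier step carries over, nor that the two steps differ: the same change on two cores in this assay, a 22-fold higher number (1.33 log units; beyond the scatter) from compound 1 to compound 3 and an at least 1.5-fold higher number (0.18 log units; that floor lies within the scatter) from compound 2 to compound 4; the limit leaves it open whether they differ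

The two methyl changes also sit at different places on different cores, so the compounds shown leave open whether the place or the core has more influence on the size of the step; the same methyl at the same carbon on the core of compound 1 would separate the two. Also open, as far as these compounds go, is what a hydroxyl or an ethyl group would do on that saturated chain carbon, and whether either would need a lower dose than the methyl.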